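Replacing 4-iodophenyl in compound 2 with pyridin-4-yl

The source may report more compounds than this note shows. Statements on the series, on what has been measured and on what is new or still open speak of the compounds shown alone.

- compound 1 `COc1ccc(-c2cc(N)c(C(=O)c3cc(OC)c(OC)c(OC)c3)s2)cc1OC`: 72 nM
- compound 2 `COc1cc(C(=O)c2sc(-c3ccc(I)cc3)cc2N)cc(OC)c1OC`: 420 nM

Both values come from a functional assay on FM3A cells (Mus musculus) for antiproliferative activity; a higher number here means a weaker inhibitor, a lower number a stronger inhibitor. Among the compounds with values here, compound 2 holds the higher of the two numbers, so it is the weaker of the pair, and compound 1 is its only neighbour. The next entry is compound 3 `COc1cc(C(=O)c2sc(-c3ccncc3)cc2N)cc(OC)c1OC`, which carries pyridin-4-yl in place of 4-iodophenyl on an aromatic carbon. Within the data shown here, only one measured step bears on this change, and it falls at the same place: a 5.8-fold higher number from compound 1 to compound 2 (0.77 log units; beyond the scatter). That step is modest and beyond the scatter, with 4-iodophenyl in place of 3,4-dimethoxyphenyl. Among the measured compounds shown here, no measured compound has a six-membered aromatic ring with a hetero atom at this place, so the direction is poorly supported. A step of similar modest size is expected in this assay, somewhat more likely towards a higher number. The expected move is a 1.7-fold higher number from compound 2 to compound 3 (0.22 log units; within the scatter). For compound 3 the estimate is 700 nM, with an expected range from 120 nM to 4000 nM.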

Compound 3, half-maximal inhibitory concentration: 150 nM
Beside the measured number, compound 3's estimate is 4.7-fold (0.67 log units) above it, within the range that was stated.
By their numbers in this assay, from the lowest: compound 1; then compound 3; then compound 2.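

In this assay, the aromatic carbon next to the ring sulfur now carries a six-membered aromatic ring with 1 hetero atom, and the swap away from 4-iodophenyl gives a 2.8-fold lower number from compound 2 to compound 3 (0.45 log units; beyond the scatter) and thus a stronger inhibitor. Set against the 3,4-dimethoxyphenyl of compound 1, the same ring gives a 2.1-fold higher number from compound 1 to compound 3 (0.32 log units; beyond the scatter) and thus a weaker inhibitor, so compound 3 ranks after compound 1 and before compound 2, with each gap beyond the scatter. Within the data shown here, the single earlier step showed only that this place responds to a change of aryl group; the series now shows that a ring with a hetero atom and without any methoxy group can recover part of what 4-iodophenyl loses, though not all of it.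

On these data alone, it stays open whether the location of the ring nitrogen matters, as pyridin-3-yl or pyridin-2-yl would show, and whether plain phenyl, 4-methoxyphenyl or a phenyl ring bearing a carboxylic acid would fit this order. Nothing measured alongside these compounds accounts for the order of the three groups.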